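A chloro swap among compounds held at limits

This account rests on a few compounds, and the source may have more. Where it says the series, first, only, none or still open, it means among the compounds named here.

In an ADME assay on CEMx174 cells (Homo sapiens) for cytotoxicity (a higher number here means that more compound is tolerated, a lower number that less compound is tolerated), compound 3 (`CCC1=C(C(=O)OCC2CCCCC2)C(c2ccc(NC)cc2)NC(=O)N1`) stands at > 10000 nM as a limit and not a number. Compound 1 (`CCC1=C(C(=O)OCC2CCCCC2)C(c2cccc(O)c2)NC(=O)N1`) also gives only a limit, > 10000 nM in this case. Compound 2 (`O=C1NC(CCl)=C(C(=O)OCC2CCCCC2)C(c2cccc(O)c2)N1`) likewise gives only a limit, here > 3000 nM in the same read-out. Among the measured compounds shown here, no compound so far has a measured number to anchor the comparison.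

Compound 4 (`CCC1=C(C(=O)OCC2CCCCC2)C(c2ccc(Cl)cc2)NC(=O)N1`) differs from compound 3 by one change, chloro in place of methylamino on an aromatic carbon and in words chloro in place of methylamino on an aromatic carbon. For the measured compounds named here, two measured steps bear on it. The nearer is a step that the two limits leave unreadable from compound 1 to compound 3 and it alters the same aryl group on the saturated ring carbon. The other is a step that the two limits leave unreadable from compound 1 to compound 2 and it also brings in a chloro, though on a saturated chain carbon. Neither gives a size to carry over, so no step beyond the scatter is expected in this assay and no direction can be argued. The expected change is a step that the limit leaves unreadable from compound 3 to compound 4 and it is only an estimate. For compound 4 the estimated half-maximal cytotoxic concentration is 12000 nM with an expected range from 4000 nM to 40000 nM and a further limit is the likeliest report.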

Compound 4, half-maximal cytotoxic concentration: > 10000 nM
Compound 4 was reported as a limit (the forecaster's own chance of this, stated with the estimate: 70%); the middle value lies beyond the limit too.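

In this assay compound 4 gives > 10000 nM, a limit and not a number. Its steps from compound 3 and from compound 1 therefore cannot be read. The compounds shown leave open what size of change, if any, these swaps bring to the half-maximal cytotoxic concentration.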